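The source may hold more compounds than are shown below. What is called first, only, known or untested is meant among the compounds shown, and "the series" means these compounds.

Measured so far in a functional assay on A549 cells (Homo sapiens) for antiproliferative activity, read by MTT assay, with a stated time of 48 h (a higher number here means a weaker inhibitor, a lower number a stronger inhibitor), are three compounds:

Compound 1 `COc1ccc(/C=C/C=C\c2cc(OC)c(OC)c(OC)c2)cc1O` gives 118 nM
Compound 2 `CCOc1cc(-c2ccc3cc[nH]c3c2)cn2c(-c3cc(OC)c(OC)c(OC)c3)nnc12` gives 626 nM
Compound 3 `COc1cc(-c2nnc3c(OC(C)C)cc(-c4ccc5[nH]ccc5c4)cn23)cc(OC)c1OC` gives 1250 nM

Compound 2 at 626 nM and compound 3 at 1250 nM lie within the usual scatter of each other, so these two cannot be ranked. Compound 3 is clearly weaker on these numbers than compound 1 at 118 nM in this comparison.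

Compound 4 `COc1cc(-c2nnc3c(OC4CC4)cc(-c4ccc5[nH]ccc5c4)cn23)cc(OC)c1OC` has not yet been measured and differs from compound 3 in one place. The change is cyclopropyl in place of isopropyl on an oxygen on an aromatic ring and it puts cyclopropyl in place of isopropyl on an oxygen on an aromatic ring.

Within the data shown here, no measured pair shows this change alone, so its size cannot be read directly from the data. Compound 2 at 626 nM differs from compound 3 in more than one place, yet the two values remain within the scatter. No change beyond the scatter is therefore expected in this assay in either direction. The estimated step of a 1.3-fold lower number from compound 3 to compound 4 (0.10 log units; within the scatter) is small. For compound 4 the estimate is 1000 nM with an expected range from 400 nM to 2500 nM as the likely outcome.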

Compound 4, half-maximal inhibitory concentration: 198 nM
Compound 4: the middle estimate sits 5.1-fold (0.70 log units) above what was measured, outside the stated range (below it).
By their numbers in this assay, from the lowest: compounds 1 and 4 (each within the scatter of the next); then compounds 2 and 3 (each within the scatter of the next).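

In this assay, the swap at this oxygen gives a 6.3-fold lower number from compound 3 to compound 4 (0.80 log units; beyond the scatter), so the group on an oxygen on an aromatic ring can matter here even when the change is small. Isopropyl and cyclopropyl each hold 3 heavy atoms, all carbon, with no hydrogen-bond donors or acceptors and no net charge, so these counts do not separate them; the visible difference is the three-membered ring in cyclopropyl. Nothing available here accounts for the size of this step.

The compounds shown leave open how a larger ring such as cyclobutyl, or a chain ending in an amine, would read on this oxygen. They also leave open whether cyclopropyl in place of isopropyl would give a similar step on the core of compound 2.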